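The source may hold more compounds than are shown below. What is called first, only, known or untested is meant among the compounds shown, and "the series" means these compounds.

The compounds here were tested in a functional assay on SUP-B15 cells (Homo sapiens) for antiproliferative activity, with a stated time of 72 h; a lower number here means that less compound is needed, a higher number that more compound is needed for the effect. Compound 1 `COc1ccc(-c2c(Br)c(=O)c3c(OC)cc(OC)cc3n2S(=O)(=O)c2ccc(OC)cc2)cc1` gives 2920 nM. Compound 2 `COc1ccc(-c2[nH]c3cc(OC)cc(OC)c3c(=O)c2I)cc1` reaches only a limit of the assay, > 86200 nM. Compound 3 `COc1ccc(-c2cc(=O)c3c(OC)cc(OC)cc3n2S(=O)(=O)c2ccc(C=O)cc2)cc1` likewise reaches only a limit of the assay, > 34400 nM. So compound 3 is one of the two compounds among the three that give no number, only a limit. Compound 4 `COc1ccc(-c2cc(=O)c3c(OC)cc(OC)cc3n2S(=O)(=O)c2ccc(C)cc2)cc1` differs from it in one place: methyl in place of formyl on an aromatic carbon, which one bond further out reads as 4-formylphenyl to 4-methylphenyl. Going by the values given here, no measured pair shows what this change does here, so any expectation rests on compound 3 alone and is uncertain. Compound 4 is expected to stay in the same region, the step that the limit leaves unreadable from compound 3 to compound 4 being small. Compound 4 is estimated at 40000 nM, within 8000 nM to 150000 nM, most likely again as a limit.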

Compound 4, half-maximal effective concentration: > 44800 nM
Compound 4: no number, only a limit; the forecaster's own chance of this, stated with the estimate: 70%; at least 1.1-fold (0.04 log units) between middle value and limit.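

In this assay, going by these compounds alone, compound 4 reaches only a limit, > 44800 nM, as compound 3 does, so no step between the two can be read. The compounds shown leave open whether methyl in place of formyl changes the effect at all.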